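This account rests on a few compounds, and the source may have more. Where it says the series, first, only, none or still open, it means among the compounds named here.

In an ADME assay on HEK293 cells (Homo sapiens) for cytotoxicity, read by MTT assay, with a stated time of 72 h (a higher number here means a weaker inhibitor, a lower number a stronger inhibitor), compound 1 `COc1ccc2[nH]cc(CCCN3CCN(C(=O)CN4CCN(C(=O)c5ccc(C)cc5)CC4)CC3)c2c1` gives 147000 nM and compound 2 `COc1ccc2[nH]cc(CCCN3CCN(C(=O)CN4CCN(C(=O)c5cccc(Cl)c5)CC4)CC3)c2c1` gives 143000 nM, so compound 2 stands level with compound 1, within the scatter. Compound 3 `COc1cccc(C(=O)N2CCN(CC(=O)N3CCN(CCCc4c[nH]c5ccc(OC)cc45)CC3)CC2)c1` carries methoxy in place of chloro on an aromatic carbon, meta to a large group: methoxy in place of chloro on an aromatic carbon. Within the data shown here, the only measured step that bears on this, a 1.0-fold lower number from compound 1 to compound 2 (0.01 log units; within the scatter), also changed a group on the aromatic ring and stayed within the scatter. No shift beyond the scatter is therefore expected in either direction. The expected step is a 1.0-fold higher number from compound 2 to compound 3 (0.01 log units; within the scatter). For compound 3 the estimate is 145000 nM, with a range of 80000 nM to 260000 nM.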

Compound 3, half-maximal inhibitory concentration: > 200000 nM
Compound 3 gave a limit, no number; the forecaster's own chance of this, stated with the estimate: 10%; middle value at least 1.3-fold (0.13 log units) from the limit.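

In this assay compound 3 reads only as a limit, not a number: the limit of > 200000 nM in this assay, at which 1 of the 3 values shown sits.

Methoxy in place of chloro gives an at least 1.3-fold higher number from compound 2 to compound 3 (0.14 log units; that floor lies within the scatter), and 3-methoxyphenyl in place of 4-methylphenyl gives an at least 1.3-fold higher number from compound 1 to compound 3 (0.13 log units; that floor lies within the scatter). So this place on the ring can carry a group whose reading leaves the measurable range, yet both floors still allow a real difference of any size or none beyond the scatter.

Going by these compounds, how far compound 3 truly lies from compound 2 stays open. So does whether an amine or a carboxylic acid on this aromatic carbon would give a number or another limit.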